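The compounds below may be only part of what the source reports. "The series", "measured", "known", "first", "only" and "open" are said of these compounds alone.

Measured in an ADME assay on microsomes from liver (Homo sapiens) for pharmacokinetics; on this read-out higher numbers stand for fast clearance and lower numbers for slow clearance:

- compound 1 `Cc1nn(C2COC2)cc1Nc1nc(N)c2c(C#N)c(N3CCC[C@H]3C)n(C)c2n1`: 46.7 mL/min/kg
- compound 2 `Cc1nn(C2CCOC2)cc1Nc1nc(N)c2c(C#N)c(N3CCC[C@H]3C)n(C)c2n1`: 76.7 mL/min/kg; 200 mL/min/kg (2 entries)
- compound 3 `Cc1nn(C)cc1Nc1nc(N)c2c(C#N)c(N3CCC[C@H]3C)n(C)c2n1`: 70 mL/min/kg

Compound 3 gives 70 mL/min/kg and lies within the scatter of compound 1, as the step of a 1.5-fold higher number from compound 1 to compound 3 (0.18 log units; within the scatter) shows. Compound 2 offers no single number for comparison: the several entries of compound 2 in this assay, 76.7 mL/min/kg; 200 mL/min/kg (2 entries).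

Compound 4 `Cc1nn(CC2(O)COC2)cc1Nc1nc(N)c2c(C#N)c(N3CCC[C@H]3C)n(C)c2n1` is derived from compound 3 by placing 3-hydroxyoxetan-3-yl in place of hydrogen on a saturated chain carbon bound to an aromatic nitrogen, so that methyl becomes (3-hydroxyoxetan-3-yl)methyl: 3-hydroxyoxetan-3-yl in place of hydrogen on a saturated chain carbon bound to an aromatic nitrogen.

Among the compounds with values here, only one measured step bears on this change. Compound 1 also carries a four-membered ring on the aromatic nitrogen where compound 3 has methyl, and that exchange gave a 1.5-fold higher number from compound 1 to compound 3 (0.18 log units; within the scatter), which stayed within the scatter. The change in this assay is therefore expected to be small, perhaps towards a lower number, and not to exceed the scatter. The expected step is a 1.4-fold lower number from compound 3 to compound 4 (0.15 log units; within the scatter). For compound 4 the estimated value is 50 mL/min/kg, with an expected range from 22 mL/min/kg to 110 mL/min/kg.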

Compound 4, clearance: 76.7 mL/min/kg
Compound 4: the middle estimate sits 1.5-fold (0.19 log units) below what was measured; measured number inside the range.
By their numbers in this assay, from the lowest: compounds 1, 3 and 4 (each within the scatter of the next).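

In this assay, within the data shown here, the earlier compounds showed only a methyl and an oxetan-3-yl on the aromatic nitrogen, and it was not yet known how this position would respond to a substituent on the saturated chain carbon. Placing 3-hydroxyoxetan-3-yl there, with its hydrogen-bond donor and four-membered ring, gave a 1.1-fold higher number from compound 3 to compound 4 (0.04 log units; within the scatter), and exchanging oxetan-3-yl for (3-hydroxyoxetan-3-yl)methyl gave a 1.6-fold higher number from compound 1 to compound 4 (0.22 log units; within the scatter), so neither change moves the clearance beyond the scatter. Nothing measured here gives a reason for this result.

On these data alone, whether an amine or a carboxylic acid on the same chain carbon would leave the clearance equally unchanged stays open. The place of compound 2 in this series also stays open, as it offers no single number: the several entries of compound 2 in this assay, 76.7 mL/min/kg; 200 mL/min/kg (2 entries)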